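The compounds below may be only part of what the source reports. "The series", "measured", "known", "first", "only" and "open" are said of these compounds alone.

Working notes on the series. The shared core is that of compound 1 `O/N=C(/Nc1cccc(C(F)(F)F)c1)c1ccc2occc2c1`, which in an assay on isolated protein for inhibition of Indoleamine 2,3-dioxygenase 1 (Homo sapiens), read by spectrophotometry (a higher number here means a weaker inhibitor, a lower number a stronger inhibitor), gives 1200 nM. Compound 2 `O/N=C(/Nc1ccc(F)c(C(F)(F)F)c1)c1ccc2occc2c1` gives 1200 nM in this assay, so the step of no change at the digits printed from compound 1 to compound 2 (within the scatter) stays inside the scatter. Compound 3 `Cc1ccc(N/C(=N/O)c2ccc3occc3c2)cc1C` returns only a limit in this assay, namely > 30000 nM. That value is the limit of > 30000 nM in this assay, at which 1 of the 3 values shown sits. Compound 1 therefore stands level with compound 2 at the digits shown, and the only other value in the set is a limit.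

The next step leads to compound 4 `O/N=C(/Nc1cccc(Oc2ccccc2)c1)c1ccc2occc2c1`; the change is phenoxy in place of trifluoromethyl on an aromatic carbon. Going by the values given here, no measured step covers this exchange. Among the compounds with values here, the single measured step, no change at the digits printed from compound 1 to compound 2 (within the scatter), adds fluorine on a different aromatic carbon and leaves the read-out unchanged within the scatter, so it says little about swapping the trifluoromethyl itself. Compound 3, which carries methyl groups instead of the trifluoromethyl, is known only as a limit, so the sensitivity of the series to changes at this part of the molecule is not established by the data at hand.

On that thin basis compound 4 is expected to lose some potency, with the step of a 2.5-fold higher number from compound 1 to compound 4 (0.40 log units; beyond the scatter) estimated as moderate. The estimate for compound 4 in this assay is 3000 nM, with a range from 600 nM to 15000 nM.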

Compound 4, half-maximal inhibitory concentration: > 30000 nM
Compound 4: no number, only a limit (the forecaster's own chance of this, stated with the estimate: 15%); middle value at least 10-fold (1.00 log units) away from the limit.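

In this assay, going by these compounds alone, phenoxy in place of trifluoromethyl on an aromatic carbon, meta to a large group, gives an at least 25-fold higher number from compound 1 to compound 4 (1.39 log units; beyond the scatter), so this is the first measured step at the carbon carrying the trifluoromethyl, and it lies beyond the scatter. Compound 4 gives > 30000 nM in this assay, and this value is a limit. Beside no change at the digits printed from compound 1 to compound 2 (within the scatter), which adds fluoro on a different aromatic carbon, the series now holds one change that stays inside the scatter and one large step at the trifluoromethyl position, and compound 4 joins compound 3 at the same limit: the limit of > 30000 nM in this assay, at which 2 of the 4 values shown sit.

The compounds shown do not separate the ring of phenoxy from its oxygen: methoxy would keep the oxygen without the ring, and benzyl would keep the ring without the oxygen. On these data alone, it also stays open whether a nitrile or a chlorine at this place would hold the read-out of compound 1, or whether that read-out depends on trifluoromethyl itself.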